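A few compounds are considered here, and "the series" means these few. Any claim that something is new, unique, unknown or untested is made for them only; others in the source may bear on it.

Going by the values given here, compound 3 `CCOC(=O)C1=Cc2ccccc2OC1(OCc1cn(CC(=O)Nc2ccccc2F)nn1)C(F)(F)F` is the one member of this small set that gives a number in a functional assay on A549 cells (Homo sapiens) for inhibition, read by MTT assay, with a stated time of 24 h (a lower number here means a stronger inhibitor, a higher number a weaker inhibitor), where compound 3 gives 50100 nM. Compound 1 `CCOC(=O)C1=Cc2ccccc2OC1(OCc1cn(-c2cccc(OC)c2)nn1)C(F)(F)F` reaches only a limit of this assay, since compound 1 gives > 150000 nM. Compound 2 `CCOC(=O)C1=Cc2ccccc2OC1(OCc1cn(CC(=O)Nc2ccccc2Br)nn1)C(F)(F)F` likewise stops at a limit, as compound 2 gives > 150000 nM. Thus compound 3 holds the only readable value here, and the two other entries sit at the limit of > 150000 nM in this assay, at which 2 of the 3 values shown sit. The step that the two limits leave unreadable from compound 1 to compound 2 cannot be sized. The step of an at least 2.9-fold lower number from compound 1 to compound 3 (0.47 log units; beyond the scatter) and the step of an at least 2.9-fold lower number from compound 2 to compound 3 (0.47 log units; beyond the scatter) both run toward compound 3.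

Compound 4 `CCOC(=O)C1=Cc2ccccc2OC1(OCc1cn(-c2ccc([N+](=O)[O-])cc2)nn1)C(F)(F)F` differs from compound 3 by 4-nitrophenyl in place of ((2-fluorophenyl)carbamoyl)methyl on an aromatic nitrogen. The change returns an aryl group directly onto the ring nitrogen, the arrangement that compound 1 carries with its 3-methoxyphenyl, and the step from compound 1 to compound 3 showed that replacing such a directly attached aryl by the ((2-fluorophenyl)carbamoyl)methyl arm lowered the number at least modestly. Reversing that direction, a higher number is expected for compound 4, and the expected step is a 3.0-fold higher number from compound 3 to compound 4 (0.48 log units; beyond the scatter). Compound 4 is therefore estimated at 150000 nM, within a range from 40000 nM to 400000 nM, with a fair chance that the assay reports only a limit.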

Compound 4, half-maximal inhibitory concentration: > 150000 nM
Compound 4 was reported as a limit; the forecaster's own chance of this, stated with the estimate: 60%; the middle value sits exactly at the limit.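

In this assay the change gives an at least 2.9-fold higher number from compound 3 to compound 4 (0.47 log units; beyond the scatter), so a second directly attached aryl group, 4-nitrophenyl, ends at the limit of the assay on the aromatic nitrogen, just as the 3-methoxyphenyl of compound 1 does. The steps that link compound 4 to compound 1 and to compound 2 cannot be read, so nothing orders these compounds among themselves. Among the four compounds, both directly attached aryl groups stop at the limit and only the carbamoylmethyl arm of compound 3 gives a number, but compound 2 goes against any simple link to that arm, since it carries the same arm with bromo in place of fluoro and still stops at the limit, which leaves most of the set without a readable value: the limit of > 150000 nM in this assay, at which 3 of the 4 values shown sit.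

The compounds shown leave open whether any directly attached aryl group can give a readable value, for instance a phenyl ring bearing an amine or a carboxylic acid. They also leave open how the arm of compound 3 responds to a longer chain between the ring nitrogen and the amide, or to chloro in place of its fluoro.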